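Removing a chain chlorine in a low-toxicity oxadiazole-free series

The compounds below may be only part of what the source reports. "The series", "measured", "known", "first", "only" and "open" are said of these compounds alone.

Compound 1, `CCCSc1nnc(Cc2ccc(Cl)cc2Cl)o1`: in a functional assay on BHK-21 cells (Mesocricetus auratus) for cytotoxicity, with a stated time of 5 days (on this read-out higher numbers stand for lower toxicity in this test and lower numbers for higher toxicity in this test), compound 1 gives > 50000 nM, which is a limit of the assay rather than a number.
Compound 2, `O=[N+]([O-])c1cccc(OCc2nnc(SCCCCl)o2)c1`: compound 2 gives > 50000 nM, again a limit.
Compound 3, `O=[N+]([O-])c1cccc(Cc2nnc(SCCCCl)o2)c1`: compound 3 gives > 50000 nM, also a limit.

Compound 3 therefore stands where every measured compound stands: at the upper edge of what this assay reports, with no cytotoxicity detected within the tested range. Within the data shown here, no two measured compounds differ in only one place, so nothing measured shows how large a single structural change moves this read-out.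

Compound 4, `CCCSc1nnc(Cc2cccc([N+](=O)[O-])c2)o1`, has not been measured. It differs from compound 3 by hydrogen in place of chloro on a saturated chain carbon, three bonds along the chain from a sulfur; seen one bond further out, the 3-chloropropyl chain on sulfur becomes a plain propyl chain. Compound 1 already carries that propyl chain on sulfur and sits at the same limit.

Because the limit of > 50000 nM in this assay, at which 3 of the 3 values shown sit, holds for all three measured compounds, the step of a number no higher from compound 3 to compound 4 (the limit leaves the size open) is expected to be none beyond the scatter, with compound 4 most likely also reported only as a limit. Compound 4 is estimated at 50000 nM, within the range 25000 nM to 100000 nM.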

Compound 4, half-maximal cytotoxic concentration: > 50000 nM
Compound 4 ended at the assay's limit (the forecaster's own chance of this, stated with the estimate: 85%); the middle value lies on the limit itself.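

No step can be read from compound 3 to compound 4, because both are reported only as a limit: the limit of > 50000 nM in this assay, at which 4 of the 4 values shown sit.

The compounds shown leave open how far each true value lies beyond that limit, and so whether changing 3-chloropropyl to propyl alters this read-out at all.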